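A few compounds are considered here, and "the series" means these few. Any claim that something is new, unique, unknown or untested is made for them only; others in the source may bear on it.

Measured compounds:
- compound 1, `C[C@@H](NC(=O)c1ccc(C#Cc2cc(F)cc(F)c2)cn1)C(C)(C)O`: 37.9%
- compound 2, `C[C@@H](NC(=O)c1nc(C#Cc2cccc(F)c2)cs1)C(C)(C)O`: 26.1%
- compound 3, `C[C@@H](NC(=O)c1ccc(C#Cc2cccc(F)c2)cn1)C(C)(C)C`: 31.2%

All three values come from an ADME assay on HEK293 cells for agonist activity at metabotropic glutamate receptor 5 (Rattus norvegicus), read by fluorescence and calcium flux; on this read-out higher numbers stand for larger maximal responses and lower numbers for smaller maximal responses. Compound 3 stands within the usual scatter of both neighbours: its gap to compound 2 and its gap to compound 1 are each smaller than the spread seen between repeated runs, so the three maximal responses cannot be told apart.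

Compound 4, `CC(C)(O)CNC(=O)c1ccc(C#Cc2cccc(F)c2)cn1`, has not yet been measured in this assay. It differs from compound 3 in one place: 2-hydroxy-2-methylpropyl in place of 1,2,2-trimethylpropyl on an amide-type nitrogen. The entering group is also carried by compound 1 and compound 2, whose values sit within the scatter of compound 3. Within the data shown here, no step of the kind is on record, so none beyond the scatter is expected in this assay, in either direction; the expected step is a number 1.8 percentage points higher from compound 3 to compound 4 (within the scatter). For compound 4 the estimate is 33%, with a range from 18% to 50%.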

Compound 4, largest response reached (reported as efficacy), in percent of the reference or control that the assay uses: 20%
For compound 4 the middle estimate is 13 percentage points above the measured one; the measured number falls inside the stated range.
By their numbers in this assay, from the lowest: compounds 4, 2, 3 and 1 (each within the scatter of the next, the first and the last beyond it).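

In this assay, among these compounds, the group on the amide-type nitrogen proves able to shift the maximal response: 2-hydroxy-2-methylpropyl in place of 1,2,2-trimethylpropyl gives a number 11.2 percentage points lower from compound 3 to compound 4 (beyond the scatter) and is the first step that can be read. The change adds a hydroxy group and removes the defined stereocentre together, so this one step cannot separate the two. Nothing measured bears on the origin of the step.

Open, as far as these compounds go, is whether a primary amine or a carboxylic acid at the chain end would give a response like that of compound 3 or compound 4.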